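The source may report more compounds than this note shows. Statements on the series, on what has been measured and on what is new or still open speak of the compounds shown alone.

Measured in an ADME assay on L132 cells (Homo sapiens) for cytotoxicity, read by MTT assay, with a stated time of 72 h; a lower number here means a stronger inhibitor, a higher number a weaker inhibitor:
- Compound 1 `COc1ccc(C2=C(c3cc(OC)c(OC)c(OC)c3)C(=O)CC2O[SiH2]C(C)(C)C)cc1OC`: > 100 ug/mL (a limit, not a number)
- Compound 2 `COc1ccc(C2=C(c3cc(OC)c(OC)c(OC)c3)C(=O)C(OC(C)=O)C2)cc1O`: 6 ug/mL

Compound 1 sits at the limit of > 100 ug/mL in this assay, at which 1 of the 2 values shown sits. Compound 3 `COc1ccc(C2=C(c3cc(OC)c(OC)c(OC)c3)C(=O)CC2O[SiH2]C(C)(C)C)cc1O` differs from it by hydrogen in place of methyl on an oxygen on an aromatic ring, turning 3,4-dimethoxyphenyl into 3-hydroxy-4-methoxyphenyl. Compound 2 also carries 3-hydroxy-4-methoxyphenyl, differs elsewhere, and gives 6 ug/mL. On that single comparison, a move towards stronger inhibition in this assay beyond the usual scatter is expected, with an at least 4.0-fold lower number from compound 1 to compound 3 (0.60 log units; beyond the scatter) as the estimated step. For compound 3 the estimated value is 25 ug/mL, with an expected range of 6 ug/mL to 100 ug/mL.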

Compound 3, half-maximal inhibitory concentration: < 1 ug/mL
Compound 3: no number, only a limit; the forecaster's own chance of this, stated with the estimate: 30%; middle value at least 25-fold (1.39 log units) away from the limit.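

In this assay, hydrogen in place of methyl on an oxygen on an aromatic ring, with the rest of the core unchanged, gives an at least 100-fold lower number from compound 1 to compound 3 (2.00 log units; beyond the scatter); this isolates the effect of the change to this one place, which compound 2, differing elsewhere as well, could not do. Compound 1 stands at a limit: the limit of > 100 ug/mL in this assay, at which 1 of the 3 values shown sits. Compound 3 also stands at a limit: the limit of < 1 ug/mL in this assay, at which 1 of the 3 values shown sits.

The full size of the step stays unread. On these data alone, whether an amine or an ethoxy group in place of this hydroxy would give a similar result remains open.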